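Replacing 4-ethylpiperazin-1-yl on the shared core

The source may report more compounds than this note shows. Statements on the series, on what has been measured and on what is new or still open speak of the compounds shown alone.

Measured in a functional assay on MCF7 cells (Homo sapiens) for inhibition, read by MTT assay, with a stated time of 72 h; on this read-out lower numbers stand for stronger inhibition and higher numbers for weaker inhibition:
- Compound 1 `CCN1CCN(c2cc(C(F)(F)F)nc(SCc3ccc(C(F)(F)F)cc3)n2)CC1`: 22000 nM
- Compound 2 `CC(C)(C)OC(=O)N1CCN(c2cc(C(F)(F)F)nc(SCc3ccc(C(F)(F)F)cc3)n2)CC1`: > 50000 nM, a limit
- Compound 3 `FC(F)(F)c1ccc(CSc2nc(N3CCN(c4ccccn4)CC3)cc(C(F)(F)F)n2)cc1`: > 50000 nM, a limit

Among the measured compounds shown here, compound 1 holds the only true number in this set, and the other two values are limits. Compound 4 `FC(F)(F)c1ccc(CSc2nc(Sc3ccccn3)cc(C(F)(F)F)n2)cc1` is still unmeasured, and its change from compound 1 is (pyridin-2-yl)sulfanyl in place of 4-ethylpiperazin-1-yl on an aromatic carbon. For the measured compounds named here, two measured steps bear on it. One is an at least 2.2-fold higher number from compound 1 to compound 2 (0.35 log units; beyond the scatter). The closer one is an at least 2.2-fold higher number from compound 1 to compound 3 (0.35 log units; beyond the scatter), which also brings in pyridin-2-yl, there on an amine nitrogen in a ring. On these data alone, compound 2 and compound 3 both sit at the limit of > 50000 nM in this assay, at which 2 of the 3 values shown sit, so the full size of these steps stays open. On this evidence, a move to a higher number is expected in this assay. The expected step is a 2.0-fold higher number from compound 1 to compound 4 (0.31 log units; beyond the scatter). The estimated value for compound 4 is 45000 nM, with an expected range of 18000 nM to 100000 nM.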

Compound 4, half-maximal inhibitory concentration: 43200 nM
Compound 4: the middle estimate sits 1.0-fold (0.02 log units) above what was measured; measured number inside the range.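

Swapping 4-ethylpiperazin-1-yl for (pyridin-2-yl)sulfanyl on this aromatic carbon gives, in this assay, a 2.0-fold higher number from compound 1 to compound 4 (0.29 log units; within the scatter). Compound 4 therefore provides a second true number, and it shows that this position can lose the six-membered non-aromatic ring, taking a sulfur-linked aromatic ring instead, without a change beyond the scatter.

On these data alone, whether an open-chain amine or a carboxylic acid on this carbon would give a lower number than compound 1 stays open. The full size of the steps to compound 2 and compound 3 cannot be read: the limit of > 50000 nM in this assay, at which 2 of the 4 values shown sit.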